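Moving the Fluorine Around the Aryl Ring

This account rests on a few compounds, and the source may have more. Where it says the series, first, only, none or still open, it means among the compounds named here.

Of the compounds shown here, two have been measured in an assay on isolated protein for positive allosteric modulation of Neuronal acetylcholine receptor; alpha4/beta2 (Homo sapiens); on this read-out higher numbers stand for an effect only at larger amounts of compound and lower numbers for an effect already at smaller amounts. Compound 1 `c1ccc(-c2cc(-c3cnn(C4CCNCC4)c3)on2)cc1` gives 100000 nM. For the measured compounds named here, compound 2 `Fc1cccc(Cl)c1-c1cc(-c2cnn(C3CCNCC3)c2)on1` gives 48 nM, the lowest of the two numbers; the step of a 2100-fold lower number from compound 1 to compound 2 (3.32 log units; beyond the scatter) is the only measured step, and it is large. Compound 3 `Fc1ccc(-c2cc(-c3cnn(C4CCNCC4)c3)on2)c(Cl)c1` has not yet been measured. The change from compound 2 is 2-chloro-4-fluorophenyl in place of 2-chloro-6-fluorophenyl on an aromatic carbon. Going by the values given here, the one measured step bears on it only loosely: it shows that the halogens on this phenyl ring can shift the number a great deal, but it compares an unsubstituted ring with a substituted one, whereas here the same two halogens remain on the ring and only the fluorine changes its place. A moderate rise in the number is therefore expected, a 6.3-fold higher number from compound 2 to compound 3 (0.80 log units; beyond the scatter). Compound 3 is estimated to give 300 nM, with a range from 60 nM to 2000 nM.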

Compound 3, half-maximal effective concentration: 220 nM
Estimate against measurement, compound 3: 1.4-fold (0.13 log units) above; measured number inside the range.
By their numbers in this assay, from the lowest: compound 2; then compound 3; then compound 1.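

With the same two halogens on the ring, moving the fluorine alone still shifts the number in this assay: 2-chloro-4-fluorophenyl in place of 2-chloro-6-fluorophenyl gives a 4.6-fold higher number from compound 2 to compound 3 (0.66 log units; beyond the scatter) and shows that the fluorine's place counts, not only its presence. The rearranged ring still stands far from the bare phenyl ring, with a 450-fold lower number from compound 1 to compound 3 (2.66 log units; beyond the scatter) and thus a large step that does not depend on the 2-chloro-6-fluorophenyl pattern alone. No measurement at hand explains why the fluorine's place matters.

From the compounds shown here alone, whether a lone chlorine without any fluorine would do as much, or whether a methoxy group or a nitrile could stand in for the fluorine, remains open. Going by these compounds, these compounds also vary only the phenyl ring, so the effect of an amide or a longer chain elsewhere on the shared core is unknown.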